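Extending the Ethoxy Chain on a Soluble Amine Core

The source may hold more compounds than are shown below. What is called first, only, known or untested is meant among the compounds shown, and "the series" means these compounds.

Measured so far:
compound 1, `C=CCOc1ccc2c(NCCN(C)C)ccnc2c1`: > 10000 ug/mL
compound 2, `CCOc1ccc2c(NCCN(C)C)ccnc2c1`: > 10000 ug/mL

In a physicochemical assay for solubility (on this read-out lower numbers stand for lower solubility and higher numbers for higher solubility), compound 1 reaches > 10000 ug/mL, which is a limit of the assay rather than a number. In this assay compound 2 likewise gives > 10000 ug/mL, again only a limit. Because of the limit of > 10000 ug/mL in this assay, at which 2 of the 2 values shown sit, the step that the two limits leave unreadable from compound 1 to compound 2 cannot be sized. Compound 2 therefore stands only at the upper boundary of what this assay reports, with no measured number behind it.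

Compound 3, `CCCCCCOc1ccc2c(NCCN(C)C)ccnc2c1`, differs from compound 2 by butyl in place of hydrogen on a saturated chain carbon, two bonds along the chain from an oxygen on an aromatic ring. No measured step speaks to this change, since the one step shown is unreadable. For compound 3 in this assay a value of 1500 ug/mL is expected, within the range 200 ug/mL to 10000 ug/mL. This estimate means a step of an at least 6.6-fold lower number from compound 2 to compound 3 (0.82 log units; beyond the scatter) from compound 2, expected to move solubility downward.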

Compound 3, solubility: > 10000 ug/mL
Compound 3: no number, only a limit (the forecaster's own chance of this, stated with the estimate: 15%); middle value at least 6.6-fold (0.82 log units) away from the limit.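

Compound 3 gives a limit rather than a number, so no step among compound 1, compound 2 and compound 3 can be read, because all three share it: the limit of > 10000 ug/mL in this assay, at which 3 of the 3 values shown sit.

The compounds shown leave open whether going from ethoxy to hexyloxy changes solubility at all, and by how much.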